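Trading an Aryl Sulfonamide for a Short Nitrile Chain

The source may report more compounds than this note shows. Statements on the series, on what has been measured and on what is new or still open speak of the compounds shown alone.

Three measured compounds share one core and differ in the group carried on the ring nitrogen. Compound 1 `CN(c1ccccc1CCCn1nnnc1[C@@H](COCc1ccccc1)NC(=O)C(C)(C)N)S(C)(=O)=O` gives 1720 nM in an assay on isolated protein for displacement of a labelled ligand from growth hormone secretagogue receptor type 1 (Homo sapiens), with a stated time of 1 h; on this read-out higher numbers stand for weaker inhibition and lower numbers for stronger inhibition. Compound 2 `CC(C)(N)C(=O)N[C@H](COCc1ccccc1)c1nnnn1CCC#N`, which carries a nitrile on a short chain, gives 2940 nM in this assay. Compound 3 `CC(C)(N)C(=O)N[C@H](COCc1ccccc1)c1nnn(Cc2ccccc2NS(C)(=O)=O)n1` is reported in this assay only as > 5000 nM, and this is a limit of the assay rather than a measured number. Compound 3 therefore stands at the weak end of what is shown, at the point described by the limit of > 5000 nM in this assay, at which 1 of the 3 values shown sits.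

Compound 4 `CC(C)(N)C(=O)N[C@H](COCc1ccccc1)c1nnn(CCCCC#N)n1` differs from compound 3 by 3-cyanopropyl in place of 2-(methanesulfonamido)phenyl on a saturated chain carbon bound to an aromatic nitrogen. Within the data shown here, no measured pair differs in exactly this way, so the size of this step is uncertain. A gain in binding is expected, because compound 2 with its nitrile-bearing chain gives 2940 nM in this assay. Compound 3, by contrast, is reported only as > 5000 nM, which is a limit of the assay. The expected step of an at least 1.2-fold lower number from compound 3 to compound 4 (0.09 log units; that floor lies within the scatter) is modest. Compound 4 is estimated at 4000 nM, within a range from 1500 nM to 12000 nM.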

Compound 4, inhibition constant: > 5000 nM
Compound 4: only a limit was reported; the forecaster's own chance of this, stated with the estimate: 40%; middle value at least 1.2-fold (0.09 log units) away from the limit.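

Compound 3 and compound 4 are both reported only as limits, so no step between them can be read, and swapping the group gives no measurable size: the limit of > 5000 nM in this assay, at which 2 of the 4 values shown sit.

The compounds shown leave open whether 3-cyanopropyl in place of 2-(methanesulfonamido)phenyl changes binding at all, and in which direction.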